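Adding a Third Methoxy Group to Compound 2

The source may report more compounds than this note shows. Statements on the series, on what has been measured and on what is new or still open speak of the compounds shown alone.

Compound 2 `COc1ccc(C(=O)/C=C/c2cc(-c3cc(OC)c(OC)c(OC)c3)n[nH]2)cc1OC` gives 5750 nM in a functional assay on HT-29 cells (Homo sapiens) for inhibition, read by sulforhodamine B assay, with a stated time of 48 h; a lower number here means that less compound is tolerated, a higher number that more compound is tolerated. Compound 3 `COc1cc(-c2cc(/C=C/C(=O)c3ccc(F)c(F)c3)[nH]n2)cc(OC)c1OC` gives 40800 nM in this assay. Compound 1 `COc1cc(-c2cc(/C=C/C(=O)c3ccc(Cl)c(Cl)c3)[nH]n2)cc(OC)c1OC` reaches only the assay limit of > 100000 nM in this assay, so no number is known for it. Among the two numbers, compound 2 holds the lowest, and the step of a 7.1-fold higher number from compound 2 to compound 3 (0.85 log units; beyond the scatter) separates it from its nearest neighbour. The steps of an at least 17-fold lower number from compound 1 to compound 2 (1.24 log units; beyond the scatter) and an at least 2.4-fold lower number from compound 1 to compound 3 (0.38 log units; beyond the scatter) both point the same way, toward lower numbers as the aryl group on the carbonyl carbon changes.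

Compound 4 `COc1cc(C(=O)/C=C/c2cc(-c3cc(OC)c(OC)c(OC)c3)n[nH]2)cc(OC)c1OC` differs from compound 2 by methoxy in place of hydrogen on an aromatic carbon. Going by the values given here, none of the measured steps adds a single group in this way; each swaps the whole aryl ring, so they bear on it only loosely. A step within or just beyond the scatter is therefore expected in this assay, its direction uncertain. Compound 4 is estimated at 4500 nM, with a likely range from 1200 nM to 18000 nM, a step of a 1.3-fold lower number from compound 2 to compound 4 (0.11 log units; within the scatter) expected from compound 2.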

Compound 4, concentration lethal to 50% of the cells: 6360 nM
For compound 4 the middle estimate is 1.4-fold (0.15 log units) below the measured one; the measured number falls inside the stated range.
By their numbers in this assay, from the lowest: compounds 2 and 4 (each within the scatter of the next); then compound 3. At a limit, above all of these: compound 1.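

The earlier steps shown here swapped the whole aryl ring on the carbonyl carbon, whereas this one adds a single methoxy group to the 3,4-dimethoxyphenyl ring, ortho to a methoxy group, and in this assay it gives a 1.1-fold higher number from compound 2 to compound 4 (0.04 log units; within the scatter) and nothing larger. This position therefore takes the added methoxy group with no readable shift in the number, so compound 2 and compound 4 cannot be put in order. Nothing among the data shown gives a reason for this result.

On these data alone, whether another group at this same position, such as an amine, a carboxylic acid or a longer alkoxy chain, would also leave the number in place stays open. Also open, as far as these compounds go, is how a ring with one methoxy group, or a plain phenyl ring, would compare.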